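Ester-to-acid change on two cinnamate cores

The source may hold more compounds than are shown below. What is called first, only, known or untested is meant among the compounds shown, and "the series" means these compounds.

Measured so far:
Compound 1 `CCOC(=O)/C=C/c1ccncc1-c1ccc2ccccc2c1`: 5380 nM
Compound 2 `O=C(O)/C=C/c1ccncc1-c1ccc2ccccc2c1`: > 10000 nM
Compound 3 `CCOC(=O)/C=C/c1ccncc1-c1ccc2c(ccn2C)c1`: 1720 nM

In a functional assay on A549 cells (Homo sapiens) for inhibition, read by sulforhodamine B assay, with a stated time of 72 h (a higher number here means a weaker inhibitor of growth, a lower number a stronger inhibitor of growth), compound 1 gives 5380 nM. Compound 2 gives only a limit of the assay, > 10000 nM, which is the limit of > 10000 nM in this assay, at which 1 of the 3 values shown sits. The change between them, (hydrogen in place of ethyl on an oxygen next to a carbonyl group), gave an at least 1.8-fold higher number from compound 1 to compound 2 (0.26 log units; that floor lies within the scatter). Compound 3 gives 1720 nM in this assay, the lowest of the two numbers; how its core differs from the core of compound 1 is not broken down here. Compound 4 `Cn1ccc2cc(-c3cnccc3/C=C/C(=O)O)ccc21` is not yet measured. It differs from compound 3 by hydrogen in place of ethyl on an oxygen next to a carbonyl group, the same change as between compound 1 and compound 2, at a place described in the same words. On the basis of that earlier step, a step of similar or somewhat larger size is expected, a 4.1-fold higher number from compound 3 to compound 4 (0.61 log units; beyond the scatter). Compound 4 is estimated at 7000 nM in this assay, between 2500 nM and 20000 nM, with a fair chance that only a limit is reported.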

Compound 4, concentration for 50% growth inhibition: > 10000 nM
Compound 4: only a limit was reported; the forecaster's own chance of this, stated with the estimate: 45%; middle value at least 1.4-fold (0.15 log units) from the limit.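

In this assay compound 4 gives > 10000 nM, which is a limit of the assay and not a number. On the core of compound 3, hydrogen in place of ethyl on an oxygen next to a carbonyl group gives an at least 5.8-fold higher number from compound 3 to compound 4 (0.76 log units; beyond the scatter), so the ester is the stronger inhibitor of growth on this core. This does not show that the change has the same size on both cores, and on the core of compound 1 the floor of the step does not clear the scatter: the same change on two cores in this assay, an at least 1.8-fold higher number (0.26 log units; that floor lies within the scatter) from compound 1 to compound 2 and an at least 5.8-fold higher number (0.76 log units; beyond the scatter) from compound 3 to compound 4; the limit leaves it open whether they differ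

As far as these compounds go, neither acid has a true number, so how far each lies from its ester stays open. From the compounds shown here alone, how an amide or a methyl ester in place of the ethoxycarbonyl group would read on either core also stays open.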